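The compounds below may be only part of what the source reports. "The series", "measured", "known", "first", "only" and "open" are said of these compounds alone.

Compound 1 `COc1ccc(CNC(=O)c2nc(C(C)(C)NC(=O)OCc3ccccc3)nc(O)c2O)cc1`: 164000 nM
Compound 2 `COc1cc(CNC(=O)c2nc(C(C)(C)NC(=O)OCc3ccccc3)nc(O)c2O)cc(OC)c1OC`: 110000 nM

Within the data shown here, in an ADME assay on C8166 cells (Homo sapiens) for cytotoxicity, read by MTT assay, with a stated time of 3 days (on this read-out higher numbers stand for lower toxicity in this test and lower numbers for higher toxicity in this test), compound 2 gives 110000 nM and compound 1 gives 164000 nM; the single measured step, a 1.5-fold lower number from compound 1 to compound 2 (0.17 log units; within the scatter), leaves the two numbers side by side rather than apart. Compound 3 `CC(C)(NC(=O)OCc1ccccc1)c1nc(O)c(O)c(C(=O)NCc2ccccc2Cl)n1` differs from compound 2 by 2-chlorophenyl in place of 3,4,5-trimethoxyphenyl on a saturated chain carbon bound to an amide-type nitrogen. Among the measured compounds shown here, only the step from compound 1 to compound 2 bears on this change: it also swaps the group on a saturated chain carbon bound to an amide-type nitrogen, and it did not move the number beyond the scatter, so no step beyond the scatter is expected here in this assay either. Compound 3 is thus expected to give about 120000 nM, between 50000 nM and 300000 nM. The expected step is a 1.1-fold higher number from compound 2 to compound 3 (0.04 log units; within the scatter).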

Compound 3, half-maximal cytotoxic concentration: 53900 nM
For compound 3 the middle estimate is 2.2-fold (0.35 log units) above the measured one; measured number inside the range.
By their numbers in this assay, from the lowest: compound 3; then compounds 2 and 1 (each within the scatter of the next).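

In this assay the group on a saturated chain carbon bound to an amide-type nitrogen can move the number beyond the scatter: swapping 3,4,5-trimethoxyphenyl for 2-chlorophenyl gives a 2.0-fold lower number from compound 2 to compound 3 (0.31 log units; beyond the scatter) and swapping 4-methoxyphenyl for 2-chlorophenyl gives a 3.0-fold lower number from compound 1 to compound 3 (0.48 log units; beyond the scatter) in the direction of higher toxicity in this test. Both steps are modest, but the two methoxy-bearing compounds alone showed no such movement. No measured evidence explains this result. The compounds shown cannot separate the arrival of the chlorine from the loss of the methoxy groups. They also leave open how a plain phenyl or a carboxylic acid would read here.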